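The source may report more compounds than this note shows. Statements on the series, on what has been measured and on what is new or still open speak of the compounds shown alone.

In an assay on isolated protein for inhibition of Amine oxidase [flavin-containing] A (Homo sapiens), read by fluorescence (a lower number here means a stronger inhibitor, a higher number a weaker inhibitor), compound 1 `O=C(/C=C/c1cccs1)c1cc(O)c(O)c([N+](=O)[O-])c1` gives 49900 nM. Two compounds that share its core but carry a saturated ring in place of the chain have also been measured: compound 2 `CC(=O)N1N=C(c2cc(O)c(O)c([N+](=O)[O-])c2)CC1c1ccc(C#N)cc1` gives 76600 nM, and compound 3 `CC(=O)N1N=C(c2cc(O)c(O)c([N+](=O)[O-])c2)CC1c1ccoc1` gives 90900 nM. Of these three numbers compound 1 gives the smallest, yet its distances to compound 2 and compound 3 both lie within the scatter, so the three compounds cannot be told apart on these data.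

Compound 4 `Cn1cc(/C=C/C(=O)c2cc(O)c(O)c([N+](=O)[O-])c2)cn1` has not yet been measured. It differs from compound 1 in one place: 1-methyl-1H-pyrazol-4-yl in place of thiophen-2-yl on a double-bonded chain carbon bound to a double-bonded chain carbon. Among the measured compounds shown here, the only measured step that resembles this exchange of one small aromatic ring for another is the one from compound 2 to compound 3, which gave a 1.2-fold higher number from compound 2 to compound 3 (0.07 log units; within the scatter). For the measured compounds named here, that step sits on a saturated ring carbon rather than on the chain, so it is only a loose guide, but it is the single comparison available and it stayed within the scatter. The expectation for compound 4 is therefore a step of about a 1.1-fold higher number from compound 1 to compound 4 (0.04 log units; within the scatter), which is no change beyond the scatter. Compound 4 is estimated to give 55000 nM, with a range from 20000 nM to 150000 nM.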

Compound 4, half-maximal inhibitory concentration: 51500 nM
Compound 4: middle estimate off by 1.1-fold (0.03 log units), on the high side; low and high end bracket the measured number.
By their numbers in this assay, from the lowest: compounds 1, 4, 2 and 3 (each within the scatter of the next).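

In this assay, the change on a double-bonded chain carbon bound to a double-bonded chain carbon gives a 1.0-fold higher number from compound 1 to compound 4 (0.01 log units; within the scatter), so thiophen-2-yl and 1-methyl-1H-pyrazol-4-yl cannot be told apart here. Among the compounds shown here, this is the first comparison made directly at this chain position, and it is not a trivial swap of rings: a five-membered aromatic ring with 1 hetero atom gives way to one with 2 hetero atoms, sulfur is replaced by nitrogen, and the count of hydrogen-bond acceptors goes from 1 to 2. No measurement beyond these numbers is available to account for the two rings reading alike.

Still open, from the compounds shown here alone, is whether a phenyl ring, a dimethylamino group or a carboxylic acid at this chain position would give a number that stands clear of the scatter from compound 1. Also open is what the two hydroxyl groups and the nitro group contribute, as they stay the same in every compound shown.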